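Amide aryl variation on the shared core: nitro analogue

This account rests on a few compounds, and the source may have more. Where it says the series, first, only, none or still open, it means among the compounds named here.

Measured compounds in a functional assay on HCC1937 cells (Homo sapiens) for antiproliferative activity, read by CCK-8 assay, with a stated time of 72 h; a higher number here means a weaker inhibitor, a lower number a stronger inhibitor:
compound 1, `COc1ccc(C(=O)Nc2cccc(-c3oc4cc(-c5ccc(F)cc5)ccc4c(=O)c3O)c2)cc1`, 5490 nM
compound 2, `Cc1cc(C(=O)Nc2cccc(-c3oc4cc(-c5ccc(F)cc5)ccc4c(=O)c3O)c2)ccc1F`, 5420 nM
compound 3, `N#Cc1ccc(C(=O)Nc2cccc(-c3oc4cc(-c5ccc(F)cc5)ccc4c(=O)c3O)c2)cc1`, 2990 nM

Compound 1 gives the highest number of the three, but its separation from the others is small: a 1.0-fold lower number from compound 1 to compound 2 (0.01 log units; within the scatter), and a 1.8-fold lower number from compound 1 to compound 3 (0.26 log units; within the scatter). Between the other two, a 1.8-fold lower number from compound 2 to compound 3 (0.26 log units; within the scatter). All three amide aryl variants therefore sit in one band in this assay.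

Compound 4, `O=C(Nc1cccc(-c2oc3cc(-c4ccc(F)cc4)ccc3c(=O)c2O)c1)c1ccc([N+](=O)[O-])cc1`, is the next member of this set. Relative to compound 1 the difference is nitro in place of methoxy on an aromatic carbon. It sits on an aromatic carbon of a six-membered aromatic ring of carbon only, para to a large group. Going by the values given here, the closest precedent is the change from methoxy to cyano at that same carbon, for which a 1.8-fold lower number from compound 1 to compound 3 (0.26 log units; within the scatter) is within the scatter; the change to 4-fluoro-3-methylphenyl, a 1.0-fold lower number from compound 1 to compound 2 (0.01 log units; within the scatter), is likewise within the scatter. Among the compounds with values here, no measured step on this carbon exceeds the scatter, so for compound 4 the step is expected to be small, a 1.6-fold lower number from compound 1 to compound 4 (0.20 log units; within the scatter), with the number for compound 4 estimated at 3500 nM, in the range 1500 nM to 8000 nM.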

Compound 4, half-maximal inhibitory concentration: 5640 nM
Compound 4: middle estimate off by 1.6-fold (0.21 log units), on the low side; low and high end bracket the measured number.
By their numbers in this assay, from the lowest: compounds 3, 2, 1 and 4 (each within the scatter of the next).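

In this assay, nitro in place of methoxy on an aromatic carbon, para to a large group, stays within the scatter (a 1.0-fold higher number from compound 1 to compound 4 (0.01 log units; within the scatter)). The other two comparisons also stay within it, against the cyano analogue (a 1.9-fold higher number from compound 3 to compound 4 (0.28 log units; within the scatter)) and against the 4-fluoro-3-methylphenyl analogue (a 1.0-fold higher number from compound 2 to compound 4 (0.02 log units; within the scatter)), so compound 4 joins compounds 1, 2 and 3 in one band, and the series now spans methoxy, cyano and nitro on this carbon without a step beyond the scatter. No measurement is available that would explain this flat result.

Still open, from the compounds shown here alone, is whether a carboxylic acid or an amine in place of nitro at this carbon would leave the band. Also open, going by these compounds, is whether a longer chain there, such as a butoxy group, would do so.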